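The source may report more compounds than this note shows. Statements on the series, on what has been measured and on what is new or still open speak of the compounds shown alone.

Measured so far:
compound 1 `Cc1[nH]ncc1-c1ccc2nc(C3COc4ccccc4C3)oc2c1`, giving 533 nM in an assay on cells for inhibition of Rho-associated protein kinase 2 (Homo sapiens); a lower number here means a stronger inhibitor, a higher number a weaker inhibitor;
compound 2 `Nc1nccc(-c2ccc3nc(C4COc5ccc(F)cc5C4)[nH]c3c2)n1`, giving "not determined" (no result reported) in this assay.

Compound 2 therefore stands nowhere on the numbers shown: it has no single value in this assay. Within the data shown here, compound 1 is the only compound with a number, and it differs from compound 2 in more than one place, so no step between them is counted. Compound 3 `Nc1nccc(-c2ccc3nc(C4COc5ccc(C(=O)NCc6ccccc6)cc5C4)[nH]c3c2)n1` differs from compound 2 by benzylcarbamoyl in place of fluoro on an aromatic carbon. With no value for compound 2, neither the size nor the direction of this step can be read from the data. Compound 3 is expected to give about 120 nM in this assay, estimated between 25 nM and 600 nM.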

Compound 3, half-maximal inhibitory concentration: 23 nM
For compound 3 the middle estimate is 5.2-fold (0.72 log units) above the measured one; measured number below the stated range.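

Among these compounds, compound 3 gives 23 nM in this assay, but compound 2 has no single value there, so no step between compound 2 and compound 3 can be read. The compounds shown leave open how benzylcarbamoyl in place of fluoro shifts the value. No evidence bearing on this result is available.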